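The source may report more compounds than this note shows. Statements on the series, on what has been measured and on what is new or still open speak of the compounds shown alone.

Measured in a functional assay on MCF7 cells (Homo sapiens) for antiproliferative activity, read by sulforhodamine B assay, with a stated time of 48 h; on this read-out higher numbers stand for weaker inhibition and lower numbers for stronger inhibition:
- compound 1 `CCc1ccccc1OS(=O)(=O)c1ccc(N2CCN(C)C2=O)cc1`: 26000 nM
- compound 2 `COc1ccccc1OS(=O)(=O)c1ccc(N2CCN(C)C2=O)cc1`: 26000 nM
- compound 3 `CN1CCN(c2ccc(S(=O)(=O)Oc3cccc(F)c3)cc2)C1=O`: > 100000 nM

Compound 3 gives > 100000 nM, which is a limit and not a number. Compound 4 `CN1CCN(c2ccc(S(=O)(=O)Oc3cccc(Br)c3)cc2)C1=O` carries bromo in place of fluoro on an aromatic carbon, meta to a large group: bromo in place of fluoro on an aromatic carbon. Going by the values given here, no measured step exchanges one halogen for another. Among the other compounds, this assay shows no change at the digits printed from compound 1 to compound 2 (within the scatter). The nearest evidence is an at least 3.8-fold higher number from compound 1 to compound 3 (0.58 log units; beyond the scatter) and an at least 3.8-fold higher number from compound 2 to compound 3 (0.58 log units; beyond the scatter), both replacing the whole group on the oxygen. On that basis, a modest move to a lower number is expected in this assay, although compound 4 may also stay at the limit. The estimated change is an at least 2.0-fold lower number from compound 3 to compound 4 (0.30 log units; that floor lies within the scatter). For compound 4 the estimated value is 50000 nM, with an expected range of 15000 nM to 100000 nM.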

Compound 4, half-maximal inhibitory concentration: 1500 nM
Compound 4: middle estimate off by 33-fold (1.52 log units), on the high side; the measured number lies below the stated range.
By their numbers in this assay, from the lowest: compound 4; then compounds 1 and 2 (each within the scatter of the next). At a limit, above all of these: compound 3.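

At this place on the ring, meta to a large group, exchanging one halogen is enough to move the number in this assay: bromo in place of fluoro gives an at least 66-fold lower number from compound 3 to compound 4 (1.82 log units; beyond the scatter). Compound 3 stands at a limit, so that step is only a floor: the limit of > 100000 nM in this assay, at which 1 of the 4 values shown sits. The 3-bromophenyl group also gives lower numbers than either earlier group on the oxygen, with a 17-fold lower number from compound 2 to compound 4 (1.24 log units; beyond the scatter) and a 17-fold lower number from compound 1 to compound 4 (1.24 log units; beyond the scatter).

As far as these compounds go, whether chloro or iodo at the same place would follow bromo stays open. So does whether a nitrile or an amine there would keep the number low.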